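The source may report more compounds than this note shows. Statements on the series, on what has been measured and on what is new or still open speak of the compounds shown alone.

Measured so far in a functional assay on A549 cells (Homo sapiens) for cytotoxicity, read by MTT assay, with a stated time of 72 h; a higher number here means a weaker inhibitor, a lower number a stronger inhibitor:
- compound 1 `COc1ccc(S(=O)(=O)c2nc3ccccc3nc2Nc2cc(OC)cc(OC)c2)cc1`: 12700 nM
- compound 2 `COc1cc(Nc2nc3ccccc3nc2S(=O)(=O)c2ccc(Br)cc2)cc(OC)c1`: 15900 nM

Compound 2 gives 15900 nM, which lies within the scatter of compound 1, so the two compounds cannot be ranked. The next compound to be read in this assay is compound 3 `O=S(=O)(c1ccc(Br)cc1)c1nc2ccccc2nc1Nc1ccc(C(F)(F)F)cc1`. It keeps the bromo group of compound 2, and the change is at the other aryl group: 4-(trifluoromethyl)phenyl in place of 3,5-dimethoxyphenyl on a nitrogen on an aromatic ring.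

Among the compounds with values here, only one measured step is available, a 1.3-fold higher number from compound 1 to compound 2 (0.10 log units; within the scatter). It stays within the scatter, but it concerns bromo in place of methoxy on an aromatic carbon and leaves the group on the nitrogen untouched. It therefore bears on this change only indirectly. Within the data shown here, the data hold no measured step at the nitrogen, and they give no direction for one.

With no direction to go on, the expected step is a 1.1-fold lower number from compound 2 to compound 3 (0.03 log units; within the scatter), and no shift beyond the scatter is assumed, though with wide uncertainty. For compound 3 the estimated value is 15000 nM, with an expected range from 5000 nM to 45000 nM.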

Compound 3, half-maximal inhibitory concentration: > 50000 nM
Compound 3 ended at the assay's limit (the forecaster's own chance of this, stated with the estimate: 15%); at least 3.3-fold (0.52 log units) between middle value and limit.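

Within the data shown here, the group on the nitrogen is the first place where a single change moves the read-out beyond the scatter in this assay: 4-(trifluoromethyl)phenyl in place of 3,5-dimethoxyphenyl gives an at least 3.1-fold higher number from compound 2 to compound 3 (0.49 log units; beyond the scatter). The only earlier step, a 1.3-fold higher number from compound 1 to compound 2 (0.10 log units; within the scatter), concerned bromo in place of methoxy on an aromatic carbon and stayed within the scatter, so the series had not yet shown any change that could be read as a real difference. Compound 3 stands at a limit of the assay and not at a number, so the step fixes a direction and only a minimum size: the limit of > 50000 nM in this assay, at which 1 of the 3 values shown sits.

The change replaces the whole aryl group in one move, so the compounds shown cannot separate the departure of the two methoxy groups from the arrival of trifluoromethyl. Open too, from the compounds shown here alone, is where a plain phenyl, or an aryl group carrying an amine or a carboxylic acid, would fall on the same nitrogen, and whether the step at this position holds with methoxy in place of bromo on the other aryl group.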